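Working notes: chloro in place of methoxy

The compounds below may be only part of what the source reports. "The series", "measured", "known", "first", "only" and "open" are said of these compounds alone.

Compound 1 `COc1ccc2nc(NC(c3cn(-c4ccccc4)nc3-c3ccc(F)cc3)c3c(O)ccc4ccccc34)sc2c1`: 33600 nM
Compound 2 `COc1cccc(-c2nn(-c3ccccc3)cc2C(Nc2nc3ccc(OC)cc3s2)c2c(O)ccc3ccccc23)c1`: 88100 nM

In a functional assay on A549 cells (Homo sapiens) for antiproliferative activity, read by MTT assay, with a stated time of 48 h (a higher number here means a weaker inhibitor, a lower number a stronger inhibitor), compound 1 holds the lower of the two numbers. Compound 3 `Oc1ccc2ccccc2c1C(Nc1nc2ccc(Cl)cc2s1)c1cn(-c2ccccc2)nc1-c1ccc(F)cc1` is next, with chloro in place of methoxy on an aromatic carbon. Going by the values given here, the one measured step, a 2.6-fold higher number from compound 1 to compound 2 (0.42 log units; beyond the scatter), lies elsewhere in the molecule and is beyond the scatter but modest. Among the compounds with values here, no measured step touches the 6-methoxy-1,3-benzothiazol-2-yl group, so it bears only loosely, and no direction can be drawn from it. The expected change is therefore no larger than that modest step, and possibly none beyond the scatter. The estimated step is a 1.1-fold lower number from compound 1 to compound 3 (0.05 log units; within the scatter). For compound 3 the expected value is 30000 nM, within an estimated range of 12000 nM to 75000 nM.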

Compound 3, half-maximal inhibitory concentration: 32200 nM
Beside the measured number, compound 3's estimate is 1.1-fold (0.03 log units) below it; the measured number falls inside the stated range.
By their numbers in this assay, from the lowest: compounds 3 and 1 (each within the scatter of the next); then compound 2.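

Working notes: in this assay the swap from 6-methoxy-1,3-benzothiazol-2-yl to 6-chloro-1,3-benzothiazol-2-yl gives a 1.0-fold lower number from compound 1 to compound 3 (0.02 log units; within the scatter) as the first measured step at this position. Methoxy and chloro on this aromatic carbon therefore cannot be told apart in this assay. No evidence is available on why the two groups read alike.

As far as these compounds go, whether an amine or a carboxylic acid at this position would read the same remains open. From the compounds shown here alone, it is also open whether chloro reads alike when 3-methoxyphenyl replaces 4-fluorophenyl.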